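This account rests on a few compounds, and the source may have more. Where it says the series, first, only, none or still open, it means among the compounds named here.

In a functional assay on A-431 cells (Homo sapiens) for antiproliferative activity, read by MTT assay, with a stated time of 72 h (on this read-out higher numbers stand for weaker inhibition and lower numbers for stronger inhibition), compound 3 `NS(=O)(=O)c1ccc(NC(=S)Nc2ccc3ncnc(Nc4ccc(F)c(Cl)c4)c3c2)cc1` gives 37600 nM, the highest of the three numbers recorded. Compound 2 `COc1cc2ncnc(Nc3ccc(C)cc3)c2cc1OCCCCC(=O)Nc1ccc(S(N)(=O)=O)cc1` gives 35500 nM, which lies within the scatter of compound 3, while compound 1 `COc1cc2ncnc(Nc3cccc(Cl)c3F)c2cc1OCCCCC(=O)Nc1ccc(S(N)(=O)=O)cc1` gives 5560 nM, the lowest of the set. Compound 4 `CCc1ccc(Nc2ncnc3ccc(NC(=S)Nc4ccc(S(N)(=O)=O)cc4)cc23)cc1` differs from compound 3 by 4-ethylphenyl in place of 3-chloro-4-fluorophenyl on a nitrogen on an aromatic ring. Among the measured compounds shown here, one measured step bears on this exchange: a 6.4-fold higher number from compound 1 to compound 2 (0.81 log units; beyond the scatter), where a phenyl carrying chlorine and fluorine likewise gave way to 4-methylphenyl. On that precedent a move toward weaker inhibition is expected, a 2.7-fold higher number from compound 3 to compound 4 (0.42 log units; beyond the scatter). Compound 3 already stands at 37600 nM, so the number expected for compound 4 in this assay lies higher still. Compound 4 is estimated at 100000 nM, with a range from 30000 nM to 300000 nM.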

Compound 4, half-maximal inhibitory concentration: 38400 nM
Estimate against measurement, compound 4: 2.6-fold (0.42 log units) above, within the range that was stated.
By their numbers in this assay, from the lowest: compound 1; then compounds 2, 3 and 4 (each within the scatter of the next).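

In this assay the exchange of 3-chloro-4-fluorophenyl for 4-ethylphenyl on a nitrogen on an aromatic ring gives a 1.0-fold higher number from compound 3 to compound 4 (0.01 log units; within the scatter) on the core of compound 3. A related exchange on the core of compound 1 gave a 6.4-fold higher number from compound 1 to compound 2 (0.81 log units; beyond the scatter) and so did not carry over to this pair, which shows no measurable dependence on this change. Nothing given accounts for this result.

On these data alone, whether an unsubstituted phenyl or a 4-methoxyphenyl on this nitrogen would read differently on the core of compound 3 stays open. So does how 4-ethylphenyl would read on the core of compound 1.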